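The compounds below may be only part of what the source reports. "The series", "measured", "known", "first", "only" and "open" are said of these compounds alone.

Compound 1 `CCC1(CCCCN2CCN(c3cccc(Cl)c3)CC2)C(=O)Nc2ccccc21` was tested in a functional assay on the whole organism (strain Wistar) with Rattus norvegicus as the target, with a stated time of 30 min (on this read-out lower numbers stand for an effect already at smaller amounts and higher numbers for an effect only at larger amounts of compound), and compound 1 gives > 10 mg/kg, which is a limit of the assay rather than a number. Compound 1 therefore stands at the limit of > 10 mg/kg in this assay, at which 1 of the 3 values shown sits. Compound 2 `CCC1(CCCCN2CCN(c3ccc(F)cc3)CC2)C(=O)Nc2ccccc21` gives 10 mg/kg in this assay. Compound 3 `CCC1(CCCCN2CCN(c3ccc(Cl)c(Cl)c3)CC2)C(=O)Nc2ccccc21` gives > 20 mg/kg, again a limit and not a number. All three differences among these compounds sit on the aryl group carried by the amine nitrogen in the ring: a number no higher from compound 1 to compound 2 (the limit leaves the size open), a step that the two limits leave unreadable from compound 1 to compound 3, and an at least 2.0-fold higher number from compound 2 to compound 3 (0.30 log units; that floor lies within the scatter).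

Compound 4 `O=C1Nc2ccccc2C1CCCCN1CCN(c2cccc(Cl)c2)CC1` differs from compound 1 at another place in the shared core: hydrogen in place of ethyl on a saturated ring carbon. Among the measured compounds shown here, none of the measured steps touches this saturated ring carbon, so none of them bears on the change, and they give no guide to its size or direction. The starting point is itself only a limit. Compound 4 is therefore expected near 15 mg/kg, in a range from 5 mg/kg to 40 mg/kg. The expected step is a step that the limit leaves unreadable from compound 1 to compound 4, which should be read as no change beyond the scatter.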

Compound 4, minimum effective dose: < 5 mg/kg
Compound 4: no number, only a limit (the forecaster's own chance of this, stated with the estimate: 50%); middle value at least 3.0-fold (0.47 log units) away from the limit.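

Replacing ethyl with hydrogen on the saturated ring carbon gives an at least 2.0-fold lower number from compound 1 to compound 4 (0.30 log units; that floor lies within the scatter) in this assay. Compound 4 stands at a limit of the assay, not at a number: the limit of < 5 mg/kg in this assay, at which 1 of the 4 values shown sits. Among the compounds shown here, the earlier compounds differed only in the aryl group on the amine nitrogen, so this is the first sign that the saturated ring carbon can also shift the dose needed, with the printed floor marking only the smallest step the two limits allow.

On these data alone, how large the step really is stays open, since only limits are available on both sides. Also open, as far as these compounds go, is how a group of intermediate or greater size on this carbon, such as methyl or a longer chain like propyl, would compare with ethyl and hydrogen, and whether the 4-fluorophenyl compound responds to the same change.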